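Swapping the Hydroxypiperidine Arm for a Propanamide

A few compounds are considered here, and "the series" means these few. Any claim that something is new, unique, unknown or untested is made for them only; others in the source may bear on it.

Measured compounds:
compound 1 `CCN1CCN(C[C@H]2CN(c3ccc(-n4cc(-c5ccccn5)cn4)c(F)c3)C(=O)O2)CC1`: 2.19
compound 2 `O=C1O[C@@H](CN2CCC(O)CC2)CN1c1ccc(-n2cc(-c3ccccn3)cn2)c(F)c1`: 1.63
compound 3 `O=C1CSC(=O)N1C[C@H]1CN(c2ccc(-n3cc(-c4ccccn4)cn3)c(F)c2)C(=O)O1`: 2.18

In a physicochemical assay for lipophilicity, read by HPLC, measured as octanol-water partition (a lower number here means a more polar compound, a higher number a more lipophilic compound), compound 2 gives the lowest of the three numbers. Moving to compound 1 reverses the modest drop seen as a number 0.56 log units lower from compound 1 to compound 2 (beyond the scatter), and moving to compound 3 gives the modest rise a number 0.55 log units higher from compound 2 to compound 3 (beyond the scatter); compound 1 and compound 3 lie within the scatter of each other, since a number 0.01 log units lower from compound 1 to compound 3 (within the scatter).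

Compound 4 `CCC(=O)NC[C@H]1CN(c2ccc(-n3cc(-c4ccccn4)cn3)c(F)c2)C(=O)O1` is not yet measured. It differs from compound 2 in one place: propanoylamino in place of 4-hydroxypiperidin-1-yl on a saturated chain carbon bound to a saturated ring carbon

Going by the values given here, the only steps that bear on this change are those that exchange the same 4-hydroxypiperidin-1-yl group, and both were modest in size. Neither of them installs a propanoylamino group, so the direction for compound 4 is read only by analogy. A modest rise beyond the scatter is expected, written as a number 0.37 log units higher from compound 2 to compound 4 (beyond the scatter). Compound 4 is therefore estimated at 2, with a range from 1.5 to 2.5.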

Compound 4, partition coefficient: 2.2
The estimate for compound 4 lay 0.20 log units below the measured number, within the range that was stated.
By their numbers in this assay, from the lowest: compound 2; then compounds 3, 1 and 4 (each within the scatter of the next).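

In this assay the change from the 2,4-dioxo-1,3-thiazolidin-3-yl group gives a number 0.02 log units higher from compound 3 to compound 4 (within the scatter) and the change from the 4-ethylpiperazin-1-yl group gives a number 0.01 log units higher from compound 1 to compound 4 (within the scatter) so a propanoylamino chain with no ring matches both ring groups at this position. The change from 4-hydroxypiperidin-1-yl gives a number 0.57 log units higher from compound 2 to compound 4 (beyond the scatter) and compound 2 now stands apart from all three other compounds, so a ring is not needed to reach the higher numbers. The hydrogen-bond donor count is the same in the leaving and entering groups of that step, so that count alone does not separate them.

From the compounds shown here alone, whether a longer acyl chain, a primary amine or a carboxylic acid on the same carbon would match compound 4 or compound 2 stays open. No measurement here explains why compound 2 stands apart.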